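Cytotoxicity notes: compound 3 to compound 4

The source may report more compounds than this note shows. Statements on the series, on what has been measured and on what is new or still open speak of the compounds shown alone.

Measured so far:
compound 1 `O=c1n(Cc2nc3ccccn3c2CCCCO)c2cnccc2n1C1CC1` gives > 100000 nM in an ADME assay on HEp-2 cells (Homo sapiens) for cytotoxicity, read by CCK-8 assay, with a stated time of 6 days (on this read-out higher numbers stand for lower toxicity in this test and lower numbers for higher toxicity in this test), a limit.
compound 2 `O=c1n(Cc2nc3cc(C(F)(F)F)ccn3c2CCCCO)c2cnccc2n1C1CC1` gives > 100000 nM in this assay, a limit.
compound 3 `O=c1n(Cc2nc3cc(Cl)ccn3c2CO)c2cnccc2n1C1CC1` gives > 100000 nM in this assay, a limit.

Compound 3 therefore stands at the limit of this assay, as do the two other values, which is the limit of > 100000 nM in this assay, at which 3 of the 3 values shown sit. Within the data shown here, the one step computed between measured compounds, a step that the two limits leave unreadable from compound 1 to compound 2, lies between two limits and has no readable size. Compound 4 `CS(=O)(=O)NC(=O)CCc1c(Cn2c(=O)n(C3CC3)c3ccncc32)nc2cc(Cl)ccn12` differs from compound 3 by ((methylsulfonyl)carbamoyl)methyl in place of hydroxy on a saturated chain carbon bound to an aromatic carbon. Among the measured compounds shown here, no measured step bears on this change, so no direction can be drawn from the data. For compound 4 the value is expected to sit again at the limit, estimated at 150000 nM with a range of 50000 nM to 500000 nM. The step that the limit leaves unreadable from compound 3 to compound 4 is expected to be none beyond the scatter.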

Compound 4, half-maximal cytotoxic concentration: > 100000 nM
Compound 4: only a limit was reported; the forecaster's own chance of this, stated with the estimate: 85%; the middle value is on the limit's open side.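

Compound 3 and compound 4 give no readable step, because both values are limits: the limit of > 100000 nM in this assay, at which 4 of the 4 values shown sit.

The compounds shown leave open how far any of these changes would shift cytotoxicity, since no compound yet gives a value short of that limit.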